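Swapping an aryl urea for an isopropyl urea

This account rests on a few compounds, and the source may have more. Where it says the series, first, only, none or still open, it means among the compounds named here.

Measured compounds:
compound 1 `CCCCCCCN(CCCCCSc1nc(N)c2c[nH]nc2n1)C(=O)NC(C)C`: "not active" (no number reported)
compound 2 `CCCCCCCN(CCCCCSc1[nH]cnc2ncnc1-2)C(=O)Nc1ccc(F)cc1F`: 200 nM

Among the compounds with values here, in an assay on microsomes from liver for inhibition of sterol O-acyltransferase 1 (Rattus norvegicus) (a higher number here means a weaker inhibitor, a lower number a stronger inhibitor), compound 2 gives 200 nM and is the only compound with a reported number. Within the data shown here, compound 1, built on a different core, gives "not active" (no number reported) in this assay; no step between compound 1 and compound 2 is defined, so their two results can only be set side by side.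

Compound 3 `CCCCCCCN(CCCCCSc1[nH]cnc2ncnc1-2)C(=O)NC(C)C` keeps the core and chain of compound 2 and differs in one place: isopropyl in place of 2,4-difluorophenyl on an amide-type nitrogen. Among the measured compounds shown here, no measured pair shows this change directly. Compound 1, which also carries an isopropyl on the urea nitrogen, gives "not active" (no number reported) in this assay, so a loss of potency beyond the scatter is expected, with the estimated step of a 13-fold higher number from compound 2 to compound 3 (1.10 log units; beyond the scatter). For compound 3 the expected result in this assay is 2500 nM, within 500 nM to 15000 nM.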

Compound 3, half-maximal inhibitory concentration: 29700 nM
Compound 3: the middle estimate sits 12-fold (1.07 log units) below what was measured, outside the stated range (above it).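

Within the data shown here, with the core and chain held fixed, this pair gives the first direct reading of the group on the urea. In this assay the change from 2,4-difluorophenyl to isopropyl on an amide-type nitrogen produces a 150-fold higher number from compound 2 to compound 3 (2.17 log units; beyond the scatter) and lies well beyond the usual scatter of repeat measurements. The group at this one position therefore has a large influence on potency here, and of the two groups compared on this core, 2,4-difluorophenyl gives the stronger inhibitor.

A single pair cannot show whether the ring, the fluorine atoms or something else accounts for the difference, and an unsubstituted phenyl, a cyclohexyl or a benzyl group at this position would be needed to separate these possibilities. No measurement shown gives a reason for the size of this step.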